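Swapping Cyclohexyl for 4-Chlorophenoxy: Expected Permeability

This account rests on a few compounds, and the source may have more. Where it says the series, first, only, none or still open, it means among the compounds named here.

Measured in an ADME assay for permeability, using PAMPA, with a stated time of 30 min, at pH 7.4; on this read-out higher numbers stand for higher permeability and lower numbers for lower permeability:
compound 1, `COc1ccc(F)cc1CNCCCNc1ccnc2cc(C3CCCCC3)ccc12`, gives 23 10^-6 cm/s
compound 2, `Fc1ccc(-c2ccc3c(NCCCNCc4ccco4)ccnc3c2)cc1`, gives 237 10^-6 cm/s
compound 3, `c1coc(CNCCCNc2ccnc3cc(C4CCCCC4)ccc23)c1`, gives 23 10^-6 cm/s

Compound 1 sits level with compound 3 at the digits shown, and together they are the lowest of the three numbers; compound 2 stands a clear distance above them.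

Compound 4, `COc1ccc(F)cc1CNCCCNc1ccnc2cc(Oc3ccc(Cl)cc3)ccc12`, has not yet been measured. It differs from compound 1 in one place: 4-chlorophenoxy in place of cyclohexyl on an aromatic carbon

Among the measured compounds shown here, two measured steps bear on this. The step of no change at the digits printed from compound 1 to compound 3 (within the scatter) shows that changing the group on the chain carbon leaves this assay unmoved. The step of a 10-fold lower number from compound 2 to compound 3 (1.01 log units; beyond the scatter) is the informative one: there the group on the aromatic carbon was changed, and the number fell by a large margin when cyclohexyl replaced an aromatic ring. The change from compound 1 to compound 4 runs the other way at the same position, with a six-membered aromatic ring entering as cyclohexyl leaves, so a rise of a similar size is expected, a 6.5-fold higher number from compound 1 to compound 4 (0.81 log units; beyond the scatter).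

Compound 4 is therefore expected to give about 150 10^-6 cm/s in this assay, with a range from 50 10^-6 cm/s to 400 10^-6 cm/s.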

Compound 4, apparent permeability: 317 10^-6 cm/s
Compound 4: middle estimate off by 2.1-fold (0.32 log units), on the low side; low and high end bracket the measured number.
By their numbers in this assay, from the lowest: compounds 1 and 3 (each within the scatter of the next); then compounds 2 and 4 (each within the scatter of the next).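

In this assay, putting 4-chlorophenoxy on the aromatic carbon in place of cyclohexyl gives a 14-fold higher number from compound 1 to compound 4 (1.14 log units; beyond the scatter), so this position moves the read-out strongly in a second pair of compounds, one with a different group on the chain carbon. Read with a 10-fold lower number from compound 2 to compound 3 (1.01 log units; beyond the scatter), this gives two pairs in which the compound with cyclohexyl has the lower number, and none of the compounds shown goes against that. This swap brings in an aromatic ring, an oxygen and a chlorine all at once, and nothing measured here ties the rise to any one of them.

Open, going by these compounds, is whether plain phenoxy, without the chlorine, would land nearer compound 4 or compound 1. Also open, on these data alone, is where a small group without a ring, such as methoxy, would fall at this carbon.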